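The source may report more compounds than this note shows. Statements on the series, on what has been measured and on what is new or still open speak of the compounds shown alone.

Working notes on the series. Compound 1 `O=C(Nc1ncc(C(=O)O)c2nc(-c3ccco3)nn12)NC1CCCCC1` in a functional assay on CHO cells for antagonist activity at adenosine receptor A2b (Homo sapiens) (a higher number here means a weaker inhibitor, a lower number a stronger inhibitor), gives only a limit, > 30000 nM. Compound 2 `Cc1ccc(CNc2ncc(C(=O)O)c3nc(-c4ccco4)nn23)cc1` likewise gives only a limit in this assay, > 10000 nM. The step that the two limits leave unreadable from compound 1 to compound 2 cannot be read, since both of its ends are limits: one end sits at the limit of > 10000 nM in this assay, at which 1 of the 2 values shown sits, and the other at the limit of > 30000 nM in this assay, at which 1 of the 2 values shown sits. Where compound 2 stands on the numbers shown is thus only that it reaches its limit in this assay; no ordering against compound 1 follows from the two values.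

Compound 3 `O=C(O)c1cnc(NCc2ccc(C(F)(F)F)cc2)n2nc(-c3ccco3)nc12` differs from compound 2 by trifluoromethyl in place of methyl on an aromatic carbon. Among the compounds with values here, no measured step bears on a change of this kind, and the only measured step is itself unreadable, so neither a size nor a direction can be taken from the measured steps. The expectation for compound 3 therefore rests on the limit of compound 2 alone, with no shown reason to expect a step beyond the scatter.

Compound 3 is expected at 20000 nM in this assay, with a range from 3000 nM to 100000 nM. The step that the limit leaves unreadable from compound 2 to compound 3 that this estimate means is expected to stay within the scatter, most likely with a limit reported again.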

Compound 3, inhibition constant: > 30000 nM
Compound 3: no number, only a limit; the forecaster's own chance of this, stated with the estimate: 70%; middle value at least 1.5-fold (0.17 log units) from the limit.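

Compound 3 gives only a limit in this assay, > 30000 nM. Compound 2 also stands at a limit, so the step between compound 2 and compound 3 cannot be read, in size or in direction. The compounds shown leave open whether trifluoromethyl in place of methyl changes anything, and whether any of compound 1, compound 2 or compound 3 has a measurable inhibition constant in this assay.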